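A few compounds are considered here, and "the series" means these few. Any claim that something is new, unique, unknown or untested is made for them only; others in the source may bear on it.

Measured so far in a functional assay on HeLa cells (Homo sapiens) for inhibition, read by CCK-8 assay, with a stated time of 72 h, tested at 8 uM; on this read-out lower numbers stand for less inhibition of growth and higher numbers for more inhibition of growth at the one concentration tested:
Compound 1 `COc1ccc(SCc2ccc(C(=O)Nc3ccccc3N)cc2)cc1`: 79.7%
Compound 2 `Nc1ccccc1NC(=O)/C=C/c1ccc(CSc2ccc(F)cc2)cc1`: 10.4%
Compound 3 `COc1ccc(SCc2ccc(C(=O)Nc3ccccc3N)cc2)cc1OC`: 79.9%

Compound 1 gives 79.7% and compound 3 gives 79.9%, and the two cannot be told apart: a number 0.2 percentage points higher from compound 1 to compound 3 (within the scatter). Going by the values given here, compound 2 gives a much lower 10.4%, but it differs from compound 1 in more than one place, so it yields no clean step.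

Compound 4 `Nc1ccccc1NC(=O)c1ccc(CSCCc2ccccc2)cc1` keeps the core of compound 1 and carries phenethyl in place of 4-methoxyphenyl on a sulfur.

Among the compounds with values here, only one measured step bears on this change, and only loosely. Compound 3 adds methoxy in place of hydrogen on an aromatic carbon of that group, with a number 0.2 percentage points higher from compound 1 to compound 3 (within the scatter). Within the data shown here, that step leaves the group in place, whereas compound 4 replaces it, so no measured step covers this swap. A moderate fall is expected, with wide uncertainty, and a result within the scatter would not be surprising.

The estimated step is a number 14.7 percentage points lower from compound 1 to compound 4 (beyond the scatter). In this assay the expected value of compound 4 is 65%, estimated to lie between 35% and 85%.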

Compound 4, percent growth inhibition at one concentration: 74.8%
The estimate for compound 4 lay 9.8 percentage points below the measured number; the measured number falls inside the stated range.
By their numbers in this assay, from the lowest: compound 2; then compounds 4, 1 and 3 (each within the scatter of the next).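

With a number 4.9 percentage points lower from compound 1 to compound 4 (within the scatter) in this assay the group on a sulfur can be replaced outright, a change larger than the added methoxy of the earlier step. Phenethyl has the same count of heavy atoms as 4-methoxyphenyl but carbon only, without the hydrogen-bond acceptor, and at this one concentration the read-out does not separate the two groups. The data at hand offer no explanation for this result.

Going by these compounds, whether a longer chain in place of phenethyl, or an amine or a carboxylic acid on that chain, would keep growth inhibition at this level remains open. A single concentration also leaves open whether compound 1 and compound 4 would separate at lower concentrations.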